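Series notes: pyridyl in place of methoxyphenyl at the chain end

The compounds below may be only part of what the source reports. "The series", "measured", "known", "first", "only" and "open" are said of these compounds alone.

Measured so far:
compound 1, `O=c1[nH]/c(=N\OCCCc2ccc(I)cc2)ccn1[C@@H]1O[C@H](COP(=O)(O)OP(=O)(O)OP(=O)(O)O)[C@@H](O)[C@H]1O`, 91 nM
compound 2, `COc1ccc(CCCO/N=c2/ccn([C@@H]3O[C@H](COP(=O)(O)OP(=O)(O)OP(=O)(O)O)[C@@H](O)[C@H]3O)c(=O)[nH]2)cc1`, 23 nM

Within the data shown here, in a functional assay on 1321-N1 cells for agonist activity at P2Y purinoceptor 4 (Homo sapiens), read by scintillation counting and inositol phosphate accumulation (on this read-out higher numbers stand for an effect only at larger amounts of compound and lower numbers for an effect already at smaller amounts), compound 2 gives the lower of the two numbers; the only other measured member, compound 1, stands one step away, the step being a 4.0-fold lower number from compound 1 to compound 2 (0.60 log units; beyond the scatter). The next member, compound 3 `O=c1[nH]/c(=N\OCCCc2cccnc2)ccn1[C@@H]1O[C@H](COP(=O)(O)OP(=O)(O)OP(=O)(O)O)[C@@H](O)[C@H]1O`, carries pyridin-3-yl in place of 4-methoxyphenyl on a saturated chain carbon, three bonds along the chain from an oxygen on an unsaturated carbon. Among the measured compounds shown here, no measured step covers this change directly. For the measured compounds named here, the one step in hand, a 4.0-fold lower number from compound 1 to compound 2 (0.60 log units; beyond the scatter), concerns a substituent on the same terminal ring and shows that this end of the chain is felt, though only modestly. Compound 3 both loses that substituent and exchanges the ring itself, so a move back towards, or somewhat past, the number of compound 1 is expected rather than no change. Compound 3 is therefore estimated at 60 nM (range 20 nM to 200 nM), which corresponds to an expected step of a 2.6-fold higher number from compound 2 to compound 3 (0.42 log units; beyond the scatter).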

Compound 3, half-maximal effective concentration: 300 nM
Compound 3: middle estimate off by 5.0-fold (0.70 log units), on the low side; the whole stated range lies below it.
By their numbers in this assay, from the lowest: compound 2; then compound 1; then compound 3.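

In this assay replacing the terminal ring itself counts for more than the substituent change seen earlier: pyridin-3-yl in place of 4-methoxyphenyl gives a 13-fold higher number from compound 2 to compound 3 (1.12 log units; beyond the scatter) and pyridin-3-yl in place of 4-iodophenyl gives a 3.3-fold higher number from compound 1 to compound 3 (0.52 log units; beyond the scatter) as well. Compound 3 therefore has the highest number of the three, so this chain end does not accept every six-membered aromatic ring equally. Nothing at hand explains the size of these steps.

From the compounds shown here alone, compound 3 differs from compound 2 both in the ring nitrogen and in the absence of the methoxy group, so the share of each remains open; an unsubstituted phenyl at the end of the propyl chain would separate them. Also open, going by these compounds, is whether a methoxy group on the pyridine ring, or pyridin-4-yl, would recover the lower numbers.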